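The source may hold more compounds than are shown below. What is called first, only, known or untested is meant among the compounds shown, and "the series" means these compounds.

Compound 1 `O=[N+]([O-])c1c(CS(=O)(=O)c2ccccc2)nc2c(C#Cc3ccccc3)cc(Cl)cn12` stands in an ADME assay on HepG2 cells (Homo sapiens) for cytotoxicity, read by MTT assay, with a stated time of 72 h (on this read-out lower numbers stand for higher toxicity in this test and higher numbers for lower toxicity in this test), only at a limit of the assay, where compound 1 gives > 3900 nM. Two close relatives give some bearing. Compound 2 `O=[N+]([O-])c1c(CS(=O)(=O)c2ccccc2)nc2c(C#Cc3ccc(CO)cc3)cc(Cl)cn12` likewise sits at a limit of the assay and gives > 15600 nM. Compound 3 `CC(O)(C#Cc1cc(Cl)cn2c([N+](=O)[O-])c(CS(=O)(=O)c3ccccc3)nc12)c1ccccc1` gives a number in this assay, 18800 nM. The steps between these three, a step that the two limits leave unreadable from compound 1 to compound 2, a step that the limit leaves unreadable from compound 1 to compound 3 and a step that the limit leaves unreadable from compound 2 to compound 3, cannot be sized because of the limits the limit of > 3900 nM in this assay, at which 1 of the 3 values shown sits, and the limit of > 15600 nM in this assay, at which 1 of the 3 values shown sits, at which two of the three values sit. All that the three values show together is that none of these compounds reaches marked toxicity in this assay.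

Compound 4 `O=[N+]([O-])c1c(CS(=O)(=O)c2ccccc2)nc2c(C#CCO)cc(Cl)cn12` differs from compound 1 by hydroxymethyl in place of phenyl on a triple-bonded carbon. Within the data shown here, no measured step puts a hydroxymethyl on the triple-bonded carbon, and the only other change at that carbon, from compound 1 to compound 3, is unreadable. The step from compound 1 to compound 4 is therefore expected to stay within the scatter, a step that the limit leaves unreadable from compound 1 to compound 4. Compound 4 is estimated at 20000 nM, within 7000 nM to 60000 nM, in this assay.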

Compound 4, half-maximal cytotoxic concentration: 10100 nM
The estimate for compound 4 lay 2.0-fold (0.30 log units) above the measured number, within the range that was stated.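

Among these compounds, with compound 4, a change at the triple-bonded carbon can be sized for the first time in this assay: a 1.9-fold lower number from compound 3 to compound 4 (0.27 log units; within the scatter). A second step, an at least 1.5-fold lower number from compound 2 to compound 4 (0.18 log units; that floor lies within the scatter), gives only a floor, so a hydroxymethyl without a ring in place of either larger group produces no readable step beyond the scatter. The step that replaces phenyl itself cannot be read: the limit of > 3900 nM in this assay, at which 1 of the 4 values shown sits.

On these data alone, it remains open whether an amine or a carboxylic acid carried on the triple-bonded carbon, in place of hydroxymethyl, would move the number in this assay beyond the scatter. As far as these compounds go, it is equally open whether a longer chain ending in a hydroxyl group would differ from compound 4 by more than the scatter.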